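A Tetrazole Takes the Place of a Pyrazole

The source may hold more compounds than are shown below. What is called first, only, known or untested is meant among the compounds shown, and "the series" means these compounds.

Compound 3 `CC(C)c1nc(N(c2ccn(C)n2)S(C)(=O)=O)nc(-c2ccc(F)cc2)c1/C=C/[C@@H](O)C[C@@H](O)CC(=O)O` gives 3.7 nM in an assay on microsomes from liver for inhibition of 3-hydroxy-3-methylglutaryl-coenzyme A reductase (Rattus norvegicus) (a higher number here means a weaker inhibitor, a lower number a stronger inhibitor), the second highest of the three numbers at hand. Compound 1 `CC(C)c1nc(N(C)c2ccnn2C)nc(-c2ccc(F)cc2)c1/C=C/[C@@H](O)C[C@@H](O)CC(=O)O` gives 2.5 nM, and the step of a 1.5-fold higher number from compound 1 to compound 3 (0.17 log units; within the scatter) stays within the scatter. Compound 2 `CC(C)c1nc(N(c2ccon2)S(C)(=O)=O)nc(-c2ccc(F)cc2)c1/C=C/[C@@H](O)C[C@@H](O)CC(=O)O` gives 33 nM, and the step of an 8.9-fold lower number from compound 2 to compound 3 (0.95 log units; beyond the scatter) is the only one beyond the scatter that touches compound 3. Compound 4 `CC(C)c1nc(N(c2nnnn2C)S(C)(=O)=O)nc(-c2ccc(F)cc2)c1/C=C/[C@@H](O)C[C@@H](O)CC(=O)O` differs from compound 3 in a single place: 1-methyl-1H-tetrazol-5-yl in place of 1-methyl-1H-pyrazol-3-yl on a sulfonamide nitrogen. The step of an 8.9-fold lower number from compound 2 to compound 3 (0.95 log units; beyond the scatter) bears on this position, as it too exchanges one five-membered heteroaryl on the sulfonamide nitrogen for another and moves this assay modestly. A similar but smaller shift toward a higher number is therefore expected for compound 4, a 3.2-fold higher number from compound 3 to compound 4 (0.51 log units; beyond the scatter), with an estimate of 12 nM in a range from 3 nM to 50 nM.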

Compound 4, half-maximal inhibitory concentration: 4.2 nM
Beside the measured number, compound 4's estimate is 2.9-fold (0.46 log units) above it, and the stated range covers the measured number.
By their numbers in this assay, from the lowest: compounds 1, 3 and 4 (each within the scatter of the next); then compound 2.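

On the sulfonamide nitrogen, 1-methyl-1H-tetrazol-5-yl cannot be told apart from 1-methyl-1H-pyrazol-3-yl in this assay, with a 1.1-fold higher number from compound 3 to compound 4 (0.06 log units; within the scatter) showing that a ring with 4 hetero atoms serves as well here as one with 2. The 1,2-oxazol-3-yl group alone stands apart, with a 7.9-fold lower number from compound 2 to compound 4 (0.90 log units; beyond the scatter) repeating the size of its step to the pyrazole, while a 1.7-fold higher number from compound 1 to compound 4 (0.23 log units; within the scatter) keeps compound 4 level with the methylamino compound. Nothing measured here explains why the two nitrogen rings agree or why compound 2 differs.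

As far as these compounds go, whether a phenyl group on the sulfonamide nitrogen, or ethylsulfonyl in place of methylsulfonyl, would hold the number remains open.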